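Diaryl ether to diarylamine in an aryl urea series

A few compounds are considered here, and "the series" means these few. Any claim that something is new, unique, unknown or untested is made for them only; others in the source may bear on it.

Three ureas carrying a basic amide tail have been measured in an assay on CHO cells for binding affinity to melanin-concentrating hormone receptor 1 (Homo sapiens), read by radioligand binding; on this read-out lower numbers stand for stronger inhibition and higher numbers for weaker inhibition. Compound 1 `CCN1CCCC1CNC(=O)c1ccc(NC(=O)Nc2ccc(Oc3ccccc3)cc2)cc1` gives 250 nM. Compound 2 `COc1cc(NC(=O)Nc2ccc(Oc3ccccc3)cc2)ccc1C(=O)NCCCN1CCCCC1` gives 50 nM. Compound 3 `COc1cc(NC(=O)Nc2cccc(Oc3ccccc3)c2)ccc1C(=O)NCCCN1CCCCC1` gives 20 nM, the lowest number of the three; its gap to compound 2 and its gap to compound 1 both exceed the usual scatter, so compound 3 stands as the most potent of the measured set. Going by the values given here, no two measured compounds differ in a single place, so no single-point step is available within the set.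

Compound 4 `COc1cc(NC(=O)Nc2cccc(Nc3ccccc3)c2)ccc1C(=O)NCCCN1CCCCC1` is the next member. It keeps the whole of compound 3 apart from one exchange: anilino in place of phenoxy on an aromatic carbon. Nothing in the measured set isolates the effect of this exchange, so the expectation rests only on the leaving and entering groups matching in heavy-atom count and ring count while differing in donor count. The step from compound 3 to compound 4 is expected to be small, most likely a modest rise in the number or none beyond the scatter, a 1.8-fold higher number from compound 3 to compound 4 (0.24 log units; within the scatter). Compound 4 is accordingly estimated at 35 nM in this assay, with a range from 10 nM to 120 nM.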

Compound 4, half-maximal inhibitory concentration: 8.1 nM
For compound 4 the middle estimate is 4.3-fold (0.64 log units) above the measured one; the whole stated range lies above it.
By their numbers in this assay, from the lowest: compound 4; then compound 3; then compound 2; then compound 1.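

In this assay, anilino in place of phenoxy on an aromatic carbon, meta to a large group, gives a 2.5-fold lower number from compound 3 to compound 4 (0.39 log units; beyond the scatter). Going by these compounds alone, this is the first single-place step available, and it shows that this position responds to a change confined to the atom linking the outer ring: the leaving and entering groups match in heavy-atom count and ring count, and they differ in that atom and in donor count. The data on hand offer nothing that accounts for the lower number or assigns it to the added donor rather than to the exchange of oxygen for nitrogen.

As far as these compounds go, it remains open whether the amine hydrogen matters, a question that an N-methylanilino or benzyl group at the same position would address. Also open, from the compounds shown here alone, is whether the exchange carries over to the other placement of the phenoxy group in compound 2, or to the ethylpyrrolidine amide tail of compound 1, since the step rests on a single pair of compounds.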